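A Methyl Added to a Compound at the Limit

This account rests on a few compounds, and the source may have more. Where it says the series, first, only, none or still open, it means among the compounds named here.

In a functional assay on RKO cells (Homo sapiens) for cytotoxicity, read by resazurin assay, with a stated time of 72 h (on this read-out higher numbers stand for weaker inhibition and lower numbers for stronger inhibition), compound 1 (`COc1cccc(Nc2nc(-n3cc(C)nc3C)cs2)c1`) gives 22500 nM as a measured number. Compound 2 (`Cc1nccn1-c1csc(Nc2cccc(Br)c2)n1`) gives > 100000 nM in this assay and this is a limit of the assay, not a number. Compound 2 therefore stands at the edge of what the read-out reports (the limit of > 100000 nM in this assay, at which 1 of the 2 values shown sits), and its true position is not known.

Compound 3 (`Cc1cn(-c2csc(Nc3cccc(Br)c3)n2)c(C)n1`) has one change from compound 2: methyl in place of hydrogen on an aromatic carbon. Among the compounds with values here, no measured pair in this small set shows what such a change does, so the expectation rests on the two values alone. Compound 1 at 22500 nM shows that a number can be read in this assay for this series. A moderate step toward stronger inhibition, beyond the scatter, is therefore expected, although compound 3 may also stay at the limit. The expected change is an estimate only (an at least 2.5-fold lower number from compound 2 to compound 3 (0.39 log units; beyond the scatter)). In this assay compound 3 is estimated at 40000 nM with an expected range from 12000 nM to 100000 nM for the coming measurement.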

Compound 3, half-maximal inhibitory concentration: > 100000 nM
Compound 3 gave a limit, no number; the forecaster's own chance of this, stated with the estimate: 35%; at least 2.5-fold (0.39 log units) between middle value and limit.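

Adding methyl at this carbon of the five-membered aromatic ring did not bring the bromo compound off the limit in this assay: compound 3 gives > 100000 nM, which is a limit and not a number. The step from compound 2 cannot be read, as both ends are limits, so the methyl may have had some effect that the read-out does not show. Compound 3 does, however, supply the first readable step in the set: with bromo in place of methoxy on an aromatic carbon, the read-out shows an at least 4.4-fold higher number from compound 1 to compound 3 (0.64 log units; beyond the scatter), which places the only measured number with the methoxy compound and leaves both bromo compounds at the edge of the assay: the limit of > 100000 nM in this assay, at which 2 of the 3 values shown sit.

What the methyl does on a compound that gives a number remains open, as the pair shown here cannot settle it. Also open, going by these compounds, is how other groups would read in place of bromo or methoxy on that aromatic carbon, for example an amine or a carboxylic acid.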